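The source may report more compounds than this note shows. Statements on the series, on what has been measured and on what is new or still open speak of the compounds shown alone.

Compound 1 `CNC(=O)c1cc(Oc2ccc(NC(=O)c3nn(-c4ccccc4C(F)(F)F)c(=O)cc3C)cc2F)ccn1`: > 40000 nM, a limit of the assay
Compound 2 `CNC(=O)c1cc(Oc2ccc(NC(=O)c3nn(-c4cccc(F)c4)c(=O)cc3C)cc2F)ccn1`: 9540 nM
Compound 3 `CNC(=O)c1cc(Oc2ccc(NC(=O)c3nn(-c4ccc(C)cc4)c(=O)cc3C)cc2F)ccn1`: 11500 nM

These readings come from a functional assay on A549 cells (Homo sapiens) for cytotoxicity, read by MTT assay, with a stated time of 72 h; on this read-out higher numbers stand for weaker inhibition and lower numbers for stronger inhibition. Compound 3 has one close neighbour among the numbers. That gap is a 1.2-fold higher number from compound 2 to compound 3 (0.08 log units; within the scatter).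

Compound 4 `Cc1ccc(-n2nc(C(=O)Nc3ccc(Oc4ncnc5ccsc45)c(F)c3)c(C)cc2=O)cc1` keeps much of compound 3 but exchanges the group on the oxygen: a group of 9 heavy atoms (6 carbon, 2 nitrogen, 1 sulfur; one five-membered aromatic ring with 1 hetero atom, one six-membered aromatic ring with 2 hetero atoms) in place of a group of 10 heavy atoms (7 carbon, 2 nitrogen, 1 oxygen; one six-membered aromatic ring with 1 hetero atom), on an oxygen on an aromatic ring. The measured steps all lie elsewhere, on an aromatic nitrogen, and the larger ones are an at least 4.1-fold lower number from compound 1 to compound 2 (0.62 log units; beyond the scatter) and an at least 3.4-fold lower number from compound 1 to compound 3 (0.54 log units; beyond the scatter). None tests the new group, so they offer only a rough size, and the direction remains uncertain. A modest fall is expected, and the estimated change is a 1.9-fold lower number from compound 3 to compound 4 (0.28 log units; within the scatter). The estimate for compound 4 is 6000 nM, with an expected range from 1500 nM to 25000 nM.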

Compound 4, half-maximal inhibitory concentration: 5890 nM
Compound 4: the middle estimate sits 1.0-fold (0.01 log units) above what was measured, and the stated range covers the measured number.
By their numbers in this assay, from the lowest: compounds 4, 2 and 3 (each within the scatter of the next). At a limit, above all of these: compound 1.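

Among these compounds, the group on the oxygen is tested here for the first time, and in this assay the exchange gives a 2.0-fold lower number from compound 3 to compound 4 (0.29 log units; within the scatter). So 2-(methylcarbamoyl)pyridin-4-yl, with its hydrogen-bond donor, can give way to a group with two aromatic rings and no such donor, without the reading moving beyond the scatter. Nothing available explains why this exchange has so little effect.

From the compounds shown here alone, it stays open whether a group carrying an amine or a carboxylic acid on this oxygen would read the same. Going by these compounds, it is also open whether the new group would behave alike with the 3-fluorophenyl of compound 2 on the aromatic nitrogen.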